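This account rests on a few compounds, and the source may have more. Where it says the series, first, only, none or still open, it means among the compounds named here.

Compound 2 `CC(=O)N1N=C(Nc2nc3ccc(Cl)cc3s2)CC1OC1=CC=C1` is the starting point. For the measured compounds named here, in a functional assay on the whole organism (Hindlimb, strain albino) with Mus musculus as the target, in the maximal electroshock model, with a stated time of 0.5 h (on this read-out lower numbers stand for an effect already at smaller amounts and higher numbers for an effect only at larger amounts of compound), compound 2 gives 212 umol/kg, which is the second highest of the three numbers measured so far. The nearest neighbour is compound 3 `O=C(/C=C/c1ccc(Cl)cc1)Nc1nc2ccc(Cl)cc2s1`, which in this assay gives 204 umol/kg, a value within the scatter of that of compound 2. The furthest is compound 1 `CC(=O)N1N=C(Nc2nc3ccccc3s2)CC1OC1=CC=C1`, which in this assay gives 382 umol/kg; the step of a 1.8-fold lower number from compound 1 to compound 2 (0.26 log units; within the scatter) stays within the scatter.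

Compound 4 `COc1ccc(C2CC(Nc3nc4ccc(Cl)cc4s3)=NN2C(C)=O)cc1O` differs from compound 2 in one place: a group of 9 heavy atoms (7 carbon, 2 oxygen; one six-membered aromatic ring of carbon only) in place of a group of 5 heavy atoms (4 carbon, 1 oxygen; one four-membered non-aromatic ring of carbon only), on a saturated ring carbon. Going by the values given here, none of the measured steps touches this saturated ring carbon; the only measured step, chloro in place of hydrogen on an aromatic carbon, was within the scatter and concerns another part of the shared core. Among the compounds with values here, with no measured step bearing on this change, no shift beyond the scatter is expected, though the uncertainty is wide. For compound 4 the expected step in this assay is a 1.2-fold higher number from compound 2 to compound 4 (0.07 log units; within the scatter). Compound 4 is therefore estimated at 250 umol/kg, in a range from 110 umol/kg to 600 umol/kg.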

Compound 4, dose for half-maximal effect: 127 umol/kg
The estimate for compound 4 lay 2.0-fold (0.29 log units) above the measured number; the measured number falls inside the stated range.
By their numbers in this assay, from the lowest: compounds 4, 3, 2 and 1 (each within the scatter of the next, the first and the last beyond it).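

The saturated ring carbon of the shared core accepts a much larger group: 3-hydroxy-4-methoxyphenyl, with its six-membered aromatic ring, replaces the group with the four-membered ring, and in this assay this gives a 1.7-fold lower number from compound 2 to compound 4 (0.22 log units; within the scatter). The swap also brings in a hydrogen-bond donor, which the departing group lacks, yet compound 2 and compound 4 cannot be told apart in this whole-animal test. No measurement at hand offers an explanation for this outcome.

On these data alone, how a plain phenyl, a methyl group or a carboxylic acid would read on this carbon remains open. Also open, as far as these compounds go, are whether the hydroxy and methoxy groups each matter on their own, and whether the same swap would read alike on the core of compound 1, which lacks the chloro.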